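Lengthening the alkyl chain of compound 1

The source may hold more compounds than are shown below. What is called first, only, known or untested is meant among the compounds shown, and "the series" means these compounds.

Compound 1, `CCCCCCCCCCCNC[C@@H]1OC[C@H](N)[C@H]1O`, stands at the top of the two numbers in hand: in a functional assay on B16-F10 cells (Mus musculus) for antiproliferative activity, read by MTT assay, with a stated time of 72 h (on this read-out higher numbers stand for weaker inhibition and lower numbers for stronger inhibition), compound 1 gives 88800 nM. Compound 3, `CCCCCCCCCCCNC[C@@H]1OC[C@H](N)[C@@H]1O`, which differs from it only in the configuration as drawn, gives 19300 nM, a step of a 4.6-fold lower number from compound 1 to compound 3 (0.66 log units; beyond the scatter). Compound 2, `CCCCCCCNC[C@@H]1OC[C@H](N)[C@@H]1O`, reaches only the limit of this assay, > 128000 nM. From compound 2 to compound 3 the change is butyl in place of hydrogen on a saturated chain carbon, and it is worth an at least 6.6-fold lower number from compound 2 to compound 3 (0.82 log units; beyond the scatter).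

Compound 4, `CCCCCCCCCCCCCCNC[C@@H]1OC[C@H](N)[C@H]1O`, is the not yet measured partner of compound 1; the change is propyl in place of hydrogen on a saturated chain carbon, ten or more bonds along the chain from an amine nitrogen. For the measured compounds named here, the one measured step that bears on it is the chain growth from compound 2 to compound 3, which lowered the number by at least a modest margin, though that step lies in the other configuration series. A lower number is therefore expected for compound 4, of a size a 2.5-fold lower number from compound 1 to compound 4 (0.40 log units; beyond the scatter), with the scatter leaving room for no change. The estimate for compound 4 is 35000 nM, between 12000 nM and 100000 nM.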

Compound 4, half-maximal inhibitory concentration: 64300 nM
Compound 4: middle estimate off by 1.8-fold (0.26 log units), on the low side; the range from low to high includes it.
By their numbers in this assay, from the lowest: compound 3; then compounds 4 and 1 (each within the scatter of the next). At a limit, above all of these: compound 2.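

In this assay, propyl in place of hydrogen on a saturated chain carbon, ten or more bonds along the chain from an amine nitrogen, gives a 1.4-fold lower number from compound 1 to compound 4 (0.14 log units; within the scatter), so at this place and in this configuration series the added chain leaves the number unmoved. The earlier chain step, an at least 6.6-fold lower number from compound 2 to compound 3 (0.82 log units; beyond the scatter), therefore does not carry over to the series of compound 1. That earlier step lies in the other configuration series and rests on a limit: the limit of > 128000 nM in this assay, at which 1 of the 4 values shown sits.

The compounds shown leave open whether a longer chain or a phenyl group at this place would move the number in the series of compound 1. They also leave open whether the configuration step seen at the shorter chain of compound 1 would hold at the chain of compound 4.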